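Replacing dichlorophenyl with dimethoxyphenyl on the enone carbonyl

The source may report more compounds than this note shows. Statements on the series, on what has been measured and on what is new or still open speak of the compounds shown alone.

Measured compounds:
compound 1 `COc1ccc(-c2cc(/C=C/C(=O)c3ccc(OC)c(OC)c3)[nH]n2)cc1` — 3510 nM
compound 2 `COc1cc(-c2cc(/C=C/C(=O)c3ccc(Cl)c(Cl)c3)[nH]n2)cc(OC)c1OC` — > 100000 nM
compound 3 `COc1ccc(-c2cc(/C=C/C(=O)c3ccc(N)cc3)[nH]n2)cc1` — 5570 nM

In a functional assay on NCI-H226 cells (Homo sapiens) for inhibition, read by sulforhodamine B assay, with a stated time of 48 h (on this read-out lower numbers stand for stronger inhibition of growth and higher numbers for weaker inhibition of growth), compound 1 gives 3510 nM. Compound 3 gives 5570 nM in this assay; these two values lie within the usual scatter of each other, so no order between them is claimed. For compound 2 this assay reports only a limit, > 100000 nM, and not a number; it sits at the limit of > 100000 nM in this assay, at which 1 of the 3 values shown sits, the weakest end of what the assay shows here.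

Compound 4 `COc1ccc(C(=O)/C=C/c2cc(-c3cc(OC)c(OC)c(OC)c3)n[nH]2)cc1OC` has not yet been measured. It differs from compound 2 by 3,4-dimethoxyphenyl in place of 3,4-dichlorophenyl on a carbonyl carbon. Compound 1 also carries a 3,4-dimethoxyphenyl on a carbonyl carbon and gives 3510 nM. Compound 2, which carries the 3,4-dichlorophenyl in that place, did not reach a measured number in this assay. On that basis the step from compound 2 to compound 4 is expected to run toward stronger inhibition of growth, and to be larger than the scatter, as an at least 16-fold lower number from compound 2 to compound 4 (1.22 log units; beyond the scatter).

Compound 4 is therefore estimated at 6000 nM in this assay, with an expected range from 1500 nM to 40000 nM.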

Compound 4, concentration for total growth inhibition: 3320 nM
Compound 4: the middle estimate sits 1.8-fold (0.26 log units) above what was measured; low and high end bracket the measured number.
By their numbers in this assay, from the lowest: compounds 4, 1 and 3 (each within the scatter of the next). At a limit, above all of these: compound 2.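

In this assay, putting 3,4-dimethoxyphenyl in place of 3,4-dichlorophenyl on a carbonyl carbon gives an at least 30-fold lower number from compound 2 to compound 4 (1.47 log units; beyond the scatter), the first step readable at this position, and it shows that this one change is enough to bring a compound from a limit to a measured number. On these data alone, compound 2 gives only a limit and not a number, so the step has a lower bound and its full size stays unknown: the limit of > 100000 nM in this assay, at which 1 of the 4 values shown sits. With 3,4-dimethoxyphenyl on the carbonyl carbon, compound 1 gives 3510 nM and compound 4 gives 3320 nM, two values within the usual scatter of each other, so the group is seen with a measured number in two compounds that differ elsewhere in one place.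

The compounds shown leave open why the step is so large, and whether 3,4-dichlorophenyl would also end at a limit on the core of compound 1. They also leave open how a phenyl carrying a nitrile or a carboxylic acid would behave on this carbonyl carbon, and whether a single methoxy group there would be enough.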